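A few compounds are considered here, and "the series" means these few. Any claim that something is new, unique, unknown or untested is made for them only; others in the source may bear on it.

In a functional assay on A2780 cells (Homo sapiens) for antiproliferative activity, read by sulforhodamine B assay, with a stated time of 72 h (on this read-out lower numbers stand for stronger inhibition and higher numbers for weaker inhibition), the measured compounds are:
Compound 1 `Cc1ncccc1CNC(=O)Nc1ccc(S(=O)(=O)c2ccccc2)cc1`: > 2000 nM, a limit
Compound 2 `O=C(NCc1cccnc1)Nc1ccc(S(=O)(=O)N2CC3(COC3)C2)cc1`: > 2000 nM, a limit
Compound 3 `O=C(NCc1cccnc1)Nc1ccc(S(=O)(=O)N2CCCNCC2)cc1`: 594 nM

Compound 3 alone gives an actual number. The other two compounds stand at the limit of > 2000 nM in this assay, at which 2 of the 3 values shown sit.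

Compound 4 `O=C(NCc1cccnc1)Nc1ccc(S(=O)(=O)N[C@H]2CC[C@H](O)CC2)cc1` carries (4-hydroxycyclohexyl)amino in place of 1,4-diazepan-1-yl on a sulfonyl sulfur. One measured step changes the group at this place: an at least 3.3-fold lower number from compound 2 to compound 3 (0.52 log units; beyond the scatter). Compound 4 gives up the group that went with the lower number in that step, so a modest move to a higher number is expected in this assay, with wide uncertainty. The expected change is a 1.5-fold higher number from compound 3 to compound 4 (0.18 log units; within the scatter). For compound 4 the estimate is 900 nM, with an expected range from 200 nM to 3000 nM.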

Compound 4, half-maximal inhibitory concentration: 369 nM
Compound 4: the middle estimate sits 2.4-fold (0.39 log units) above what was measured, within the range that was stated.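

In this assay, the step to the new group is a 1.6-fold lower number from compound 3 to compound 4 (0.21 log units; within the scatter), so (4-hydroxycyclohexyl)amino, with a ring of carbon only, stands level with 1,4-diazepan-1-yl on the sulfonyl sulfur. A second ring nitrogen is therefore not required at this place for activity at this level. The step from the spiro-bearing compound is an at least 5.4-fold lower number from compound 2 to compound 4 (0.73 log units; beyond the scatter), and its size is a bound resting on a limit: the limit of > 2000 nM in this assay, at which 2 of the 4 values shown sit.

The compounds shown leave open how an amine or a carboxylic acid in place of the hydroxyl on the cyclohexyl ring would read. They also leave open whether the other arrangement of the 2 defined stereocentres would read the same.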